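Notes on the chloro to trifluoromethyl step in the series

This account rests on a few compounds, and the source may have more. Where it says the series, first, only, none or still open, it means among the compounds named here.

The compounds share the core of compound 1 `Cc1ccc(NC(=O)c2ccc(F)cc2)cc1-n1cc(-c2cnc3cccnn23)cn1`. In a functional assay on K562 cells (Homo sapiens) for antiproliferative activity, read by CCK-8 assay, with a stated time of 24 h (a higher number here means a weaker inhibitor, a lower number a stronger inhibitor), compound 1 gives 12400 nM. Compound 2 `Cc1ccc(NC(=O)c2ccc(CN3CCN(C)CC3)cc2)cc1-n1cc(-c2cnc3cccnn23)cn1` sits at a limit of this assay: in this assay compound 2 gives < 2 nM, which is a limit and not a number. Compound 3 `Cc1ccc(NC(=O)c2cccc(Cl)c2)cc1-n1cc(-c2cnc3cccnn23)cn1` gives 5080 nM in this assay and holds the lowest of the two plain numbers; the measured step here is a 2.4-fold lower number from compound 1 to compound 3 (0.39 log units; beyond the scatter), with 3-chlorophenyl in place of 4-fluorophenyl on the carbonyl carbon. The other measured step, an at least 6200-fold lower number from compound 1 to compound 2 (3.79 log units; beyond the scatter), with (4-methylpiperazin-1-yl)methyl in place of fluoro on an aromatic carbon, brings in a far larger group and offers no guide to a swap of one small substituent for another.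

Compound 4 `Cc1ccc(NC(=O)c2cccc(C(F)(F)F)c2)cc1-n1cc(-c2cnc3cccnn23)cn1` differs from compound 3 by trifluoromethyl in place of chloro on an aromatic carbon. For the measured compounds named here, no measured pair covers this change directly; the only comparable small-substituent step, a 2.4-fold lower number from compound 1 to compound 3 (0.39 log units; beyond the scatter), was modest. For compound 4 the expected step is a 1.3-fold lower number from compound 3 to compound 4 (0.10 log units; within the scatter), within or near the scatter. The estimate for compound 4 in this assay is 4000 nM, within 1500 nM to 12000 nM.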

Compound 4, half-maximal inhibitory concentration: < 2 nM
Compound 4 was reported as a limit; the forecaster's own chance of this, stated with the estimate: 2%; middle value at least 2000-fold (3.30 log units) away from the limit.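

The swap of chloro for trifluoromethyl on this aromatic carbon, meta to a large group, gives an at least 2500-fold lower number from compound 3 to compound 4 (3.40 log units; beyond the scatter), so a change from one heavy atom to four is enough here to reach the limit of this assay. Until now only compound 2, with its (4-methylpiperazin-1-yl)methyl group, stood at that limit, and an at least 6200-fold lower number from compound 1 to compound 4 (3.79 log units; beyond the scatter) shows that a substituent with no ring can stand there too. How far either step truly runs cannot be read, and compound 2 and compound 4 cannot be placed in order: the limit of < 2 nM in this assay, at which 2 of the 4 values shown sit.

Open, on these data alone, is how a methyl, a nitrile or an amine on the same aromatic carbon would read, and whether any of them would stay close to chloro or reach the limit. Also open, as far as these compounds go, is what trifluoromethyl and (4-methylpiperazin-1-yl)methyl would give together on one ring.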